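A few compounds are considered here, and "the series" means these few. Any claim that something is new, unique, unknown or untested is made for them only; others in the source may bear on it.

Compound 2 `O=S(=O)(c1cccc(F)c1)c1ccc2c(c1)CCC[C@H]2CNCCO` stands at the lowest of the two numbers recorded in an assay on isolated protein for displacement of a labelled ligand from 5-hydroxytryptamine receptor 6 (Homo sapiens); on this read-out lower numbers stand for stronger inhibition and higher numbers for weaker inhibition: compound 2 gives 0.126 nM, while compound 1 `NC[C@@H]1CCCc2cc(S(=O)(=O)Cc3ccccc3)ccc21` gives 158 nM, a gap far beyond the scatter. Compound 3 `CN(C[C@@H]1CCCc2cc(S(=O)(=O)c3cccc(F)c3)ccc21)S(C)(=O)=O` differs from compound 2 in one place: methyl(methylsulfonyl)amino in place of (2-hydroxyethyl)amino on a saturated chain carbon bound to a saturated ring carbon. For the measured compounds named here, no measured pair shows this change, and it removes the hydrogen-bond donors of the leaving group. A weakening well beyond the scatter is expected, with the step of a 240-fold higher number from compound 2 to compound 3 (2.38 log units; beyond the scatter). Compound 3 is therefore estimated at 30 nM, within a range from 3 nM to 300 nM.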

Compound 3, inhibition constant: 0.398 nM
Estimate against measurement, compound 3: 75-fold (1.88 log units) above; measured number outside the range, below it.
By their numbers in this assay, from the lowest: compound 2; then compound 3; then compound 1.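

Putting methyl(methylsulfonyl)amino in place of (2-hydroxyethyl)amino on this saturated chain carbon gives only a 3.2-fold higher number from compound 2 to compound 3 (0.50 log units; beyond the scatter) in this assay. The step is real but modest, so this position accepts a larger group that carries no hydrogen-bond donors, and those donors are not essential for a strong result here. Nothing available explains why the loss is so small. 

The compounds shown leave open whether a free carboxylic acid or a longer chain ending in a dimethylamine would be accepted at this place equally well.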